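Ring-nitrogen substituent trimmed: compound 1 to compound 3

The source may report more compounds than this note shows. Statements on the series, on what has been measured and on what is new or still open speak of the compounds shown alone.

Two compounds of this series have been run in an ADME assay on S9 fraction (Rattus norvegicus) for metabolic stability, with a stated time of 60 min; on this read-out higher numbers stand for a more stable compound and lower numbers for a less stable compound. Within the data shown here, compound 1 `CO[C@H]1CC[C@@H](CN2CC(=O)Nc3ncc(-c4ccc(C(C)(C)O)nc4)nc32)CC1` gives 39% in this assay, the lowest of the two numbers so far. Compound 2 `COCCN1C(=O)CNc2ncc(-c3ccc(C(C)(C)O)nc3)nc21`, which carries a different group on the ring nitrogen of the shared core, gives 89% in this assay, a number well beyond the usual scatter above that of compound 1. Among the measured compounds shown here, no step between two measured compounds that differ in a single place is available, so the two values only show that the group on this nitrogen can move the read-out strongly.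

Compound 3 `CO[C@H]1CC[C@@H](N2CC(=O)Nc3ncc(-c4ccc(C(C)(C)O)nc4)nc32)CC1` is the next compound to be measured in this assay. It differs from compound 1 in one place: 4-methoxycyclohexyl in place of (4-methoxycyclohexyl)methyl on a nitrogen on an aromatic ring in a ring. The change is small and keeps the ring and the methoxy group. Compound 3 is expected to show a modest step upward, a number 11 percentage points higher from compound 1 to compound 3 (beyond the scatter), though a result within the scatter of compound 1 would not surprise. The estimate for compound 3 in this assay is 50%, in a range from 30% to 72%.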

Compound 3, percent of the compound remaining: 87%
The estimate for compound 3 lay 37 percentage points below the measured number; measured number outside the range, above it.
By their numbers in this assay, from the lowest: compound 1; then compounds 3 and 2 (each within the scatter of the next).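

In this assay, among these compounds, 4-methoxycyclohexyl in place of (4-methoxycyclohexyl)methyl on the ring nitrogen gives a number 48 percentage points higher from compound 1 to compound 3 (beyond the scatter), the first step that can be read at a single place. The six-membered carbon ring, the methoxy group, both defined stereocentres and the counts of hydrogen-bond donors and acceptors are the same on both sides, while the heavy-atom count of the group goes from 9 to 8. Among the compounds shown here, the earlier values showed only that the group on this nitrogen can move the read-out, whereas this pair shows that a large step can come from a change this small, with the ring and the methoxy group kept.

Nothing at hand explains the step. Still open, on these data alone, is how the read-out responds to other groups on this nitrogen, such as a longer chain carrying the cyclohexyl ring, a plain cyclohexyl ring without the methoxy group, or an amine or hydroxyl group in place of the methoxy group.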